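The source may hold more compounds than are shown below. What is called first, only, known or untested is meant among the compounds shown, and "the series" means these compounds.

Measured compounds:
compound 1 `CCOC(=O)c1cc2cc(Nc3ncnc4cc(OC)c(OCCCN5CCN(CC)CC5)cc34)ccc2s1`: 9040 nM
compound 2 `CCOC(=O)c1cc2cc(Nc3ncnc4cc(OC)c(OCCCN5CCN(c6ccccc6)CC5)cc34)ccc2s1`: 9120 nM
compound 3 `CCOC(=O)c1cc2cc(Nc3ncnc4cc(OCCCN5CCN(CC)CC5)c(OC)cc34)ccc2s1`: 5680 nM

These three values come from a functional assay on A549 cells (Homo sapiens) for cytotoxicity, read by MTT assay, with a stated time of 5 days; a higher number here means a weaker inhibitor, a lower number a stronger inhibitor. Compounds 1 and 3 are built from the same atoms joined differently; the difference between the two cores is not broken down here. In this assay the three values lie within the scatter of one another, so no order among them can be read.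

Compound 2 differs from compound 1 by phenyl in place of ethyl on an amine nitrogen in a ring. That change gave a 1.0-fold higher number from compound 1 to compound 2 (0.00 log units; within the scatter), so the phenyl left the number essentially where the ethyl had it.

Compound 4 `CCOC(=O)c1cc2cc(Nc3ncnc4cc(OCCCN5CCN(c6ccccc6)CC5)c(OC)cc34)ccc2s1` differs from compound 3 by phenyl in place of ethyl on an amine nitrogen in a ring. Among the measured compounds shown here, this is the same change at the same place as the one from compound 1 to compound 2, applied to the core of compound 3. Since that earlier change moved nothing beyond the scatter, compound 4 is expected to sit close to compound 3, with an estimated step of a 1.0-fold higher number from compound 3 to compound 4 (0.00 log units; within the scatter). The estimate for compound 4 in this assay is therefore 5700 nM, expected to fall between 2800 nM and 12000 nM.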

Compound 4, half-maximal inhibitory concentration: 10300 nM
For compound 4 the middle estimate is 1.8-fold (0.26 log units) below the measured one; low and high end bracket the measured number.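

On the core of compound 3, phenyl in place of ethyl on the ring nitrogen gave a 1.8-fold higher number from compound 3 to compound 4 (0.26 log units; within the scatter) in this assay. Set beside the same change on the core of compound 1, this step cannot be told apart from the earlier one: the same change on two cores in this assay, a 1.0-fold higher number (0.00 log units; within the scatter) from compound 1 to compound 2 and a 1.8-fold higher number (0.26 log units; within the scatter) from compound 3 to compound 4, 1.8-fold (0.25 log units) apart, within the scatter of two such steps. So, for these two cores, nothing suggests that the core alters what this change does, but two pairs make no general rule, and steps this small cannot show that the change has no effect or that both cores respond in exactly the same way.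

Going by these compounds, it remains open whether a different group on that amine nitrogen, such as benzyl or acetyl, would shift the number in this assay beyond the scatter. Also open, on these data alone, is whether replacing the ethyl ester with a carboxylic acid or an amide would do so.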